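Ethyl in place of trifluoromethyl: cytotoxicity outlook

The source may hold more compounds than are shown below. What is called first, only, known or untested is meant among the compounds shown, and "the series" means these compounds.

Compound 2 `CC(C)C[C@H](NC(=O)c1cc2c(OC(F)(F)F)cccc2[nH]1)C(=O)N[C@H](C#N)C[C@@H]1CCCNC1=O` has been tested in a toxicity assay on Vero C1008 cells (Chlorocebus sabaeus) for cytotoxicity, read by CCK-8 assay (on this read-out lower numbers stand for higher toxicity in this test and higher numbers for lower toxicity in this test), and gives only a limit there, > 100000 nM. So compound 2 is known only to lie at the edge of what this test can report, not as a number. Its companion, compound 1 `COc1cccc2[nH]c(C(=O)N[C@@H](CC(C)C)C(=O)N[C@H](C#N)C[C@@H]3CCCNC3=O)cc12`, likewise gives only a limit in this assay, > 200000 nM. For the measured compounds named here, the one step between measured compounds, a step that the two limits leave unreadable from compound 1 to compound 2, is therefore unreadable: one value sits at the limit of > 200000 nM in this assay, at which 1 of the 2 values shown sits, and the other at the limit (the limit of > 100000 nM in this assay, at which 1 of the 2 values shown sits), and no size can be drawn from the pair.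

Compound 3 `CCOc1cccc2[nH]c(C(=O)N[C@@H](CC(C)C)C(=O)N[C@H](C#N)C[C@@H]3CCCNC3=O)cc12` is the next member and differs from compound 2 by ethyl in place of trifluoromethyl on an oxygen on an aromatic ring. Going by the values given here, no measured step bears on this change in a readable way, so no shift in this assay can be transferred from the two measured compounds; the only guidance is that both of them reached a limit. Compound 3 is therefore expected to give about 200000 nM in this assay, with a range from 80000 nM to 600000 nM. The estimated step that the limit leaves unreadable from compound 2 to compound 3 is expected to be none beyond the scatter, and compound 3 is expected most likely to be reported as a limit again.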

Compound 3, half-maximal cytotoxic concentration: > 200000 nM
Compound 3 was reported as a limit; the forecaster's own chance of this, stated with the estimate: 85%; the middle value sits exactly at the limit.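

Compound 3 also gives only a limit in this assay, > 200000 nM, so neither the step from compound 1 to compound 3 nor the step from compound 2 to compound 3 can be read. The compounds shown leave open how far compound 1, compound 2 and compound 3 truly differ in cytotoxicity, and whether changing the group on the oxygen shifts this read-out at all.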